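The source may hold more compounds than are shown below. What is called first, only, known or untested is meant among the compounds shown, and "the series" means these compounds.

Values so far in an in vitro ADME assay on microsomes (Homo sapiens) for metabolic stability; a higher number here means that the compound lasts longer, a lower number that the compound disappears faster
- compound 1 `CCC(CC)Nc1nc(OC)c(-c2ccc(Cl)cc2Cl)nc1C` gives 0.933 h
- compound 2 `CCc1nc(N(CC2CC2)CC2CC2)c(CC)nc1-c1ccc(Cl)cc1Cl` gives 0.133 h
- compound 3 `CCOc1ccc(-c2nc(OC)c(NC(CC)CC)nc2C)c(Cl)c1` gives 2 h

Compound 2 has the lowest number of the three, and its gaps to compound 1 and compound 3 both lie beyond the scatter. The next compound to be measured is compound 4 `CCc1nc(-c2ccc(Cl)cc2Cl)c(CC)nc1NC(CC)CC`, reached from compound 2 by one change on an aromatic carbon: (pentan-3-yl)amino in place of bis(cyclopropylmethyl)amino on an aromatic carbon. (Pentan-3-yl)amino replaces bis(cyclopropylmethyl)amino, and the rest of the structure stays the same.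

Going by the values given here, no measured pair differs in one place, so the effect of this change has not been measured directly. Among the compounds with values here, the only indirect guide is that (pentan-3-yl)amino is also carried by compound 1, at 0.933 h, and by compound 3, at 2 h. Both differ from compound 4 elsewhere in the structure, so a rise is expected only with caution. The expected rise, beyond the scatter, is estimated as a 3.4-fold higher number from compound 2 to compound 4 (0.53 log units; beyond the scatter). For compound 4 the estimated half-life is 0.45 h, with an expected range of 0.18 h to 1.1 h.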

Compound 4, half-life: 0.283 h
Estimate against measurement, compound 4: 1.6-fold (0.20 log units) above; the measured number falls inside the stated range.
By their numbers in this assay, from the lowest: compound 2; then compound 4; then compound 1; then compound 3.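

Going by these compounds alone, replacing bis(cyclopropylmethyl)amino with (pentan-3-yl)amino on the aromatic carbon para to a 2,4-dichlorophenyl group gives the first direct reading at this position in this assay: a 2.1-fold higher number from compound 2 to compound 4 (0.33 log units; beyond the scatter), so the number responds to this group while the rest of the structure stays the same. The entering group differs in several ways at once, with fewer heavy atoms, no ring and a hydrogen-bond donor, and this single step cannot separate those differences. Nothing available bears on why the number rises.

Open, as far as these compounds go, is whether a morpholine or a dimethylamino group at this position would shift the half-life further. Also open, from the compounds shown here alone, is whether the same exchange gives a step of similar size on the cores of compound 1 and compound 3.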